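The compounds below may be only part of what the source reports. "The series", "measured", "known", "first", "only" and "open" are said of these compounds alone.

Compound 1, `COc1cc(CCc2ccccn2)cc(OC)c1O`: in a functional assay on A549 cells (Homo sapiens) for antiproliferative activity, read by MTT assay, with a stated time of 72 h (a lower number here means a stronger inhibitor, a higher number a weaker inhibitor), compound 1 gives only a limit, > 25000 nM.
Compound 2, `COc1ccc(CCc2ccccc2Cl)cc1OC`: in this assay compound 2 also gives a limit, > 25000 nM.
Compound 3, `COc1ccccc1CCc1cc(OC)c(O)c(OC)c1`: in this assay compound 3 gives 1740 nM.

Compound 1 stands at the limit of > 25000 nM in this assay, at which 2 of the 3 values shown sit, so no number is known for it, only that its potency lies beyond what the assay resolves. Going by the values given here, of the three measured compounds only compound 3 yields a number, and it differs from compound 1 and from compound 2 in more than one place, so no single step between measured compounds can be counted here, and nothing can be said about the size of any measured change.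

Compound 4, `COc1cc(CCc2ccncc2)cc(OC)c1O`, keeps the core of compound 1 and differs from it in one place: pyridin-4-yl in place of pyridin-2-yl on a saturated chain carbon, two bonds along the chain from an aromatic carbon. Because compound 1 sits at the limit of > 25000 nM in this assay, at which 2 of the 3 values shown sit, the step to compound 4 cannot be counted from a number. The change is small in kind, so compound 4 is expected to remain weak, and the step of an at least 1.2-fold lower number from compound 1 to compound 4 (0.09 log units; that floor lies within the scatter) is expected to lie within the usual scatter, with a fair chance that only a limit is reported again. For compound 4 the estimate in this assay is 20000 nM, expected to fall between 5000 nM and 60000 nM.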

Compound 4, half-maximal inhibitory concentration: > 25000 nM
Compound 4: only a limit was reported; the forecaster's own chance of this, stated with the estimate: 55%; middle value at least 1.2-fold (0.09 log units) from the limit.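

In this assay compound 1 and compound 4 both give only limits, so the step between them cannot be read: the limit of > 25000 nM in this assay, at which 3 of the 4 values shown sit.

The compounds shown leave open whether pyridin-2-yl and pyridin-4-yl differ at all in their effect on the core of compound 1, and which single change to that core would yield a measurable number.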